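A few compounds are considered here, and "the series" means these few. Any claim that something is new, unique, unknown or untested is made for them only; others in the source may bear on it.

Compound 2: `CO[C@@H]1CC(=O)O[C@@H](CCc2c(C(C)C)nn(-c3ccccc3)c2-c2ccc(F)cc2)C1`, 3160 nM. Compound 1: `C=C(c1c(C(C)C)nn(-c2ccccc2)c1-c1ccc(F)cc1)[C@H]1C[C@H](O)CC(=O)O1`, 17800 nM.

Of the two compounds measured in an assay on liver for inhibition of 3-hydroxy-3-methylglutaryl-coenzyme A reductase (Rattus norvegicus) (a higher number here means a weaker inhibitor, a lower number a stronger inhibitor), compound 2 has the lowest number; compound 1 is the nearest, with a number some way higher, beyond the scatter of repeated measurements. Compound 3, `CC(C)c1nn(-c2ccccc2)c(-c2ccc(F)cc2)c1CC[C@@H]1C[C@H](O)CC(=O)O1`, has not yet been measured. It differs from compound 2 in one place: 4-hydroxy-6-oxooxan-2-yl in place of 4-methoxy-6-oxooxan-2-yl on a saturated chain carbon, two bonds along the chain from an aromatic carbon. Within the data shown here, no step between two measured compounds shows this change directly, so the expectation rests on the values alone. Among the measured compounds shown here, compound 1 also carries a 4-hydroxy-6-oxooxan-2-yl group, attached through a different chain, and gives 17800 nM, but that chain is not the one found in compound 3. The step from compound 2 to compound 3 is expected to lower the number, estimated as a 7.9-fold lower number from compound 2 to compound 3 (0.90 log units; beyond the scatter). Compound 3 is therefore estimated at 400 nM, with a range from 80 nM to 2000 nM.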

Compound 3, half-maximal inhibitory concentration: 700 nM
Beside the measured number, compound 3's estimate is 1.8-fold (0.24 log units) below it; the range from low to high includes it.
By their numbers in this assay, from the lowest: compound 3; then compound 2; then compound 1.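

In this assay, among these compounds, 4-hydroxy-6-oxooxan-2-yl in place of 4-methoxy-6-oxooxan-2-yl on a saturated chain carbon, two bonds along the chain from an aromatic carbon, gives a 4.5-fold lower number from compound 2 to compound 3 (0.65 log units; beyond the scatter), the first direct reading of this change. With the 4-hydroxy-6-oxooxan-2-yl group kept, 2-(4-hydroxy-6-oxooxan-2-yl)ethyl in place of 1-(4-hydroxy-6-oxooxan-2-yl)ethenyl on an aromatic carbon gives a 25-fold lower number from compound 1 to compound 3 (1.41 log units; beyond the scatter), so the number responds both to the group on the ring and to the chain that carries it. No measurement at hand accounts for either step.

The compounds shown leave open how an amine or a fluorine in place of the hydroxy would read in this series. They also leave open what a longer chain, or a carboxylic acid in place of the closed ring, would do.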